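Cytotoxicity notes: benzothiazole in place of the ester

The compounds below may be only part of what the source reports. "The series", "measured", "known", "first", "only" and "open" are said of these compounds alone.

The series shares the core of compound 2, `COC(=O)c1ccc(NCc2cncn2Cc2ccc(F)cc2F)cc1-c1ccccc1`. In a toxicity assay on NIH3T3 cells (Mus musculus) for cytotoxicity, read by resazurin assay (on this read-out lower numbers stand for an effect already at smaller amounts and higher numbers for an effect only at larger amounts of compound), compound 2 gives > 1000 nM, which is a limit of the assay and not a number. Compound 1, `COC(=O)c1ccc(NCc2cncn2Cc2cccc(Br)c2)cc1-c1ccccc1`, in this assay gives > 10000 nM, again a limit. Compound 3, `COC(=O)c1ccc(NCc2cncn2Cc2cccc(-c3ccccc3)c2)cc1-c1ccccc1`, in this assay gives "not determined" (no result reported). The step that the two limits leave unreadable from compound 1 to compound 2 is therefore unreadable, since it runs from the limit of > 10000 nM in this assay, at which 1 of the 3 values shown sits, to the limit of > 1000 nM in this assay, at which 1 of the 3 values shown sits. For the measured compounds named here, compound 2 thus stands at one limit, the only other value shown is also a limit, and the third entry carries no number at all.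

Compound 4, `Fc1ccc(Cn2cncc2CNc2ccc(-c3nc4ccccc4s3)c(-c3ccccc3)c2)c(F)c1`, differs from compound 2 in one place: 1,3-benzothiazol-2-yl in place of methoxycarbonyl on an aromatic carbon. The methoxycarbonyl leaves and a 1,3-benzothiazol-2-yl enters on an aromatic carbon of the six-membered aromatic ring of carbon only. Going by the values given here, no measured step bears on this change; the single step from compound 1 to compound 2 is unreadable and sits elsewhere in the molecule. Nothing beyond the scatter can be expected in this assay on these grounds. The step that the limit leaves unreadable from compound 2 to compound 4 is therefore expected to be nothing beyond the scatter. Compound 4 is estimated at 8000 nM, between 1500 nM and 40000 nM, with a limit rather than a number as the most likely report.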

Compound 4, half-maximal effective concentration: > 1000 nM
Compound 4 was reported as a limit; the forecaster's own chance of this, stated with the estimate: 65%; the middle value is on the limit's open side.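

In this assay compound 4 gives > 1000 nM, a limit and not a number. For the compounds shown here, compound 2 sits at the same limit, so no step between compound 2 and compound 4 can be read. The compounds shown leave open whether 1,3-benzothiazol-2-yl in place of methoxycarbonyl shifts the value in this assay at all, and where either compound's actual value lies.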